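Swapping a Benzyl Substituent Before Cytotoxicity Is Measured

The compounds below may be only part of what the source reports. "The series", "measured", "known", "first", "only" and "open" are said of these compounds alone.

Compound 1 `COC(=O)c1ccc(NCc2cncn2Cc2ccccc2C)cc1-c1ccccc1`: 10000 nM
Compound 2 `c1ccc(-c2ccc(Cn3cncc3CNc3ccc(-c4ccccc4)cc3)cc2)cc1`: > 10000 nM, a limit

In a toxicity assay on NIH3T3 cells (Mus musculus) for cytotoxicity, read by resazurin assay (on this read-out lower numbers stand for an effect already at smaller amounts and higher numbers for an effect only at larger amounts of compound), compound 1 gives 10000 nM. Compound 2 shows > 10000 nM, a limit of the assay. Among the measured compounds shown here, compound 1 therefore holds the only actual number here, with the limit of > 10000 nM in this assay, at which 1 of the 2 values shown sits, standing beside it. Compound 3 `COC(=O)c1ccc(NCc2cncn2Cc2cccc(Cl)c2)cc1-c1ccccc1` keeps the core of compound 1 and carries the change (3-chlorophenyl in place of 2-methylphenyl on a saturated chain carbon bound to an aromatic nitrogen). For the measured compounds named here, no measured pair shows a change of this kind, so no step size is known from the data; in this assay the step is expected to stay within the usual scatter. The step is expected to be no change at the digits printed from compound 1 to compound 3 (within the scatter). Compound 3 is expected to give 10000 nM, between 4000 nM and 25000 nM.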

Compound 3, half-maximal effective concentration: > 10000 nM
Compound 3: only a limit was reported; the forecaster's own chance of this, stated with the estimate: 50%; the middle value lies on the limit itself.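

In this assay, the change from 2-methylbenzyl to 3-chlorobenzyl gives a number no lower from compound 1 to compound 3 (the limit leaves the size open), so this change at this position brings no cytotoxic effect at smaller amounts. Compound 3 reads > 10000 nM, which is a limit and not a number. The size of the step therefore cannot be read, and limits now make up most of this small set: the limit of > 10000 nM in this assay, at which 2 of the 3 values shown sit.

The compounds shown leave open whether an amine or a carboxylic acid at this place would also leave the read-out unmoved. They also cannot tell how far beyond the limit compound 3 lies.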